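The compounds below may be only part of what the source reports. "The series", "measured", "known", "first", "only" and "open" are said of these compounds alone.

Measured compounds:
- compound 1 `CN(Cc1ccccc1)C(=O)c1cc2c(Cc3ccccc3)n[nH]c2cc1O`: in a functional assay on A2780 cells (Homo sapiens) for antiproliferative activity, read by resazurin assay, with a stated time of 72 h (on this read-out lower numbers stand for stronger inhibition and higher numbers for weaker inhibition), compound 1 gives 980 nM
- compound 2 `CN(Cc1ccccc1Cl)C(=O)c1cc2c(Cc3ccccc3)n[nH]c2cc1O`: in this assay compound 2 gives 1100 nM

Compound 1 and compound 2 stand close together; the step of a 1.1-fold higher number from compound 1 to compound 2 (0.05 log units; within the scatter) is within the scatter, so the two numbers cannot be ordered against each other, and compound 1 is simply one of two near-identical values on a shared core.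

Compound 3 `Cc1ccccc1CN(C)C(=O)c1cc2c(Cc3ccccc3)n[nH]c2cc1O` is the unmeasured member. Against compound 1 the difference is methyl in place of hydrogen on an aromatic carbon. For the measured compounds named here, the only measured step that bears on it is the one for a chloro group, another small substituent on an aromatic carbon, a 1.1-fold higher number from compound 1 to compound 2 (0.05 log units; within the scatter), and it stayed within the scatter. Nothing in the two measured numbers points to a step beyond the scatter in this assay in either direction for a methyl entering at an aromatic carbon of the shared core.

For compound 3 the expected step from compound 1 is therefore a 1.0-fold higher number from compound 1 to compound 3 (0.01 log units; within the scatter), essentially none. The estimate for compound 3 in this assay is 1000 nM, with a range from 450 nM to 2200 nM.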

Compound 3, half-maximal inhibitory concentration: 4400 nM
Compound 3: middle estimate off by 4.4-fold (0.64 log units), on the low side; measured number outside the range, above it.
By their numbers in this assay, from the lowest: compounds 1 and 2 (each within the scatter of the next); then compound 3.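

In this assay, the change from benzyl to 2-methylbenzyl gives a 4.5-fold higher number from compound 1 to compound 3 (0.65 log units; beyond the scatter) and so moves the number beyond the scatter, which the chloro group on this aromatic carbon, ortho to a large group, did not do. The two substituents also separate from each other at this one place: methyl in place of chloro gives a 4.0-fold higher number from compound 2 to compound 3 (0.60 log units; beyond the scatter), so the outcome here depends on which group enters and not only on the loss of the hydrogen. No measurement at hand accounts for this separation between methyl and chloro.

From the compounds shown here alone, whether the weaker inhibition stays with methyl alone or also appears with groups such as ethyl or methoxy on this carbon remains open, as does whether an amine or a carboxylic acid there would track with chloro or with methyl. The compounds shown vary only this one place, so the effect of a methyl on any other carbon of that ring cannot be judged from them.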